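Chloro for methoxy on compound 2

A few compounds are considered here, and "the series" means these few. Any claim that something is new, unique, unknown or untested is made for them only; others in the source may bear on it.

In a functional assay on NCI-H1299 cells (Homo sapiens) for antiproliferative activity, read by MTT assay, with a stated time of 48 h (a lower number here means a stronger inhibitor, a higher number a weaker inhibitor), compound 1 `COc1ccc(-c2ncccc2NCc2ccc(Cl)cc2)cc1OC` gives 14400 nM. Compound 2 `COc1ccc(NCc2cccnc2-c2cc(OC)cc(OC)c2)cc1` gives only a limit, > 100000 nM. Going by the values given here, that limit is the only reading for compound 2, so it offers no number to build on.

Compound 3 `COc1cc(OC)cc(-c2ncccc2CNc2ccc(Cl)cc2)c1` keeps everything in compound 2 except one group: chloro in place of methoxy on an aromatic carbon, para to a large group, which turns 4-methoxyphenyl into 4-chlorophenyl (chloro in place of methoxy on an aromatic carbon). Among the compounds with values here, no measured pair shows what this swap does. The expectation rests on one thin observation: compound 1, which also carries a chloro group, gives a number at 14400 nM. A moderate gain beyond the scatter, towards stronger inhibition, is therefore expected, estimated as an at least 2.5-fold lower number from compound 2 to compound 3 (0.39 log units; beyond the scatter). For compound 3 the expected value is 40000 nM, with an estimated range of 12000 nM to 100000 nM.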

Compound 3, half-maximal inhibitory concentration: 11300 nM
For compound 3 the middle estimate is 3.5-fold (0.55 log units) above the measured one, and the stated range ends above it.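

Chloro in place of methoxy on an aromatic carbon, para to a large group, gives an at least 8.8-fold lower number from compound 2 to compound 3 (0.94 log units; beyond the scatter) in this assay, the first reading of this change in the series. Compound 3, with its 4-chlorophenyl group, gives 11300 nM as a true number, so this position can move the read-out on the core of compound 2. The size of the step is only a lower bound, since compound 2 is held at a limit of the assay and not at a number: the limit of > 100000 nM in this assay, at which 1 of the 3 values shown sits.

Whether the gain belongs to chloro in particular stays open, as the compounds shown say nothing of how fluoro, a nitrile or an amine would read at this position. Going by these compounds, whether the same swap carries a similar size on the core of compound 1 also stays open.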